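Methoxy for Methyl on the Aryl Arm of a Hydroxamate

The source may hold more compounds than are shown below. What is called first, only, known or untested is meant among the compounds shown, and "the series" means these compounds.

Measured compounds:
Compound 1, `Cc1ccc(-c2nc(CNc3ccc(C(=O)NO)cc3)n(-c3ccccc3)n2)cc1`: 62.2%
Compound 2, `O=C(NO)c1ccc(NCc2nc(-c3ccc(Br)o3)nn2-c2ccccc2)cc1`: 55.8%
Compound 3, `COc1ccc(-n2nc(-c3ccccc3)nc2CNc2ccc(C(=O)NO)cc2)cc1`: 63.4%

Three hydroxamic acids sharing one core have been tested in an assay on Sf9 cells for inhibition of protein deacetylase HDAC6 (Homo sapiens), read by fluorescence, with a stated time of 40 min, tested at 100 nM; a higher number here means more inhibition at the concentration tested (going by the name of the read-out), a lower number less inhibition. Compound 1 stands second highest of the three numbers; its nearest neighbour is compound 3, and compound 2 lies furthest from it, though both gaps are within the scatter, so the three cannot be placed in any order.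

The unmeasured compound 4, `COc1ccc(-c2nc(CNc3ccc(C(=O)NO)cc3)n(-c3ccccc3)n2)cc1`, differs from compound 1 in one place: methoxy in place of methyl on an aromatic carbon.

Among the measured compounds shown here, only one step between measured compounds differs in a single place, a number 6.4 percentage points lower from compound 1 to compound 2 (within the scatter), and it concerns a different exchange, a 5-bromofuran-2-yl for the whole 4-methylphenyl group, so it does not bear directly on a methoxy for a methyl. Compound 3 carries a methoxyphenyl group elsewhere on the core and its value sits close to that of compound 1, which is the only indirect hint available. The case for a shift in this assay in either direction is therefore weak, and the expected step of a number 0.2 percentage points lower from compound 1 to compound 4 (within the scatter) is none beyond the scatter.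

Compound 4 is accordingly estimated at 62%, with a range from 48% to 76%.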

Compound 4, a percentage reported as inhibition, at one concentration (the size of the read-out at that concentration, not a potency): 77.6%
The estimate for compound 4 lay 15.6 percentage points below the measured number; measured number outside the range, above it.
By their numbers in this assay, from the lowest: compounds 2, 1 and 3 (each within the scatter of the next); then compound 4.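

In this assay, among the compounds shown here, methoxy in place of methyl on the aromatic carbon para to a large group gives a number 15.4 percentage points higher from compound 1 to compound 4 (beyond the scatter) and so provides the first step that clears the scatter, showing that this position is not indifferent to a small change: the exchange swaps a methyl for a methoxy and leaves the rest of compound 1 untouched. The earlier step from the 4-methylphenyl to the 5-bromofuran-2-yl group stayed within the scatter, whereas 4-methoxyphenyl in place of 5-bromofuran-2-yl gives a number 21.8 percentage points higher from compound 2 to compound 4 (beyond the scatter) and separates these two aryl arms as well. No measurement shown here accounts for the rise.

From the compounds shown here alone, whether the gain belongs to the methoxy group alone stays open, since a hydroxyl, an ethoxy, a dimethylamino group or a fluorine on the same carbon would show how narrowly this position responds. The read-out also comes from a single concentration, so how far the step carries over into a potency remains unsettled.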